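Tert-butyl in place of methyl: compound 1 to compound 4

A few compounds are considered here, and "the series" means these few. Any claim that something is new, unique, unknown or untested is made for them only; others in the source may bear on it.

Compound 1 `C=C(Br)C(=O)Nc1cccc(/C=C2\SC(=O)N(Cc3ccc(C)cc3)C2=O)c1` gives 1000 nM. Compound 2 `Nc1cccc(/C=C2\SC(=O)N(Cc3ccc(Cl)cc3)C2=O)c1` gives 246000 nM. Compound 3 `Nc1cccc(/C=C2\SC(=O)N(Cc3ccccc3)C2=O)c1` gives only a limit of the assay, > 250000 nM.

All three were tested in a functional assay on FM3A cells (Mus musculus) for cytotoxicity, read by cell counting, with a stated time of 2 days; a lower number here means a stronger inhibitor, a higher number a weaker inhibitor. Compound 1 gives the lowest of the two numbers; compound 2 gives a higher number, and that gap is beyond the scatter. Among the measured compounds shown here, the one measured step at the same place, hydrogen in place of chloro on an aromatic carbon, reads an at least 1.0-fold higher number from compound 2 to compound 3 (0.00 log units; that floor lies within the scatter), a step that does not leave the scatter; it is bounded by the limit of > 250000 nM in this assay, at which 1 of the 3 values shown sits.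

Compound 4 `C=C(Br)C(=O)Nc1cccc(/C=C2\SC(=O)N(Cc3ccc(C(C)(C)C)cc3)C2=O)c1` differs from compound 1 by tert-butyl in place of methyl on an aromatic carbon. For the measured compounds named here, no measured pair exchanges methyl for tert-butyl, so the only guide is the step from compound 2 to compound 3, which shows that changing the group at this place did not move the number beyond the scatter. The step from compound 1 to compound 4 is therefore expected to be small or none beyond the scatter, a 1.5-fold higher number from compound 1 to compound 4 (0.18 log units; within the scatter). Compound 4 is estimated at 1500 nM, within 400 nM to 6000 nM.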

Compound 4, half-maximal inhibitory concentration: 5200 nM
Beside the measured number, compound 4's estimate is 3.5-fold (0.54 log units) below it, within the range that was stated.
By their numbers in this assay, from the lowest: compound 1; then compound 4; then compound 2. At a limit, above all of these: compound 3.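

In this assay, tert-butyl in place of methyl on an aromatic carbon para to a large group gives a 5.2-fold higher number from compound 1 to compound 4 (0.72 log units; beyond the scatter) and so shows that the number responds to the group at this position, on the core of compound 1. The earlier pair at this place, compound 2 and compound 3, exchanged chloro for hydrogen and gave no step beyond the scatter, and compound 3 stands at a limit, so that pair could not show this; compound 4, by contrast, still reads as a number and not a limit, so the change from 4-methylphenyl to 4-(tert-butyl)phenyl raises the number without taking it to the limit of the assay. Nothing measured in this series gives a reason for the size of this step.

From the compounds shown here alone, what an amine, a carboxylic acid or a longer chain at this position would give on the core of compound 1 stays open. Methyl and tert-butyl fix a single step and not a trend, and how chloro or hydrogen would read on that same core is equally open.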